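This account rests on a few compounds, and the source may have more. Where it says the series, first, only, none or still open, it means among the compounds named here.

Within the data shown here, compound 2, `CCCNC(=O)c1cc(Oc2ccc(NC(=O)c3cc4cccnc4n(-c4ccc(F)cc4)c3=O)cc2)ccn1`, is one of two compounds measured in a functional assay on NCI-H460 cells (Homo sapiens) for antiproliferative activity, read by MTT assay, with a stated time of 72 h (a higher number here means a weaker inhibitor, a lower number a stronger inhibitor), and in that assay compound 2 gives 120 nM. Among the measured compounds shown here, the only comparison available is to compound 1, `CCCNC(=O)c1cc(Oc2ccc(NC(=O)c3cc4cccnc4n(-c4ccccc4)c3=O)cc2)ccn1`, which in this assay gives 110 nM; the step of a 1.1-fold higher number from compound 1 to compound 2 (0.04 log units; within the scatter) is the sole measured step, and it lies within the scatter, so the two numbers cannot be ordered.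

Compound 3, `CCCNC(=O)c1cc(Oc2ccc(NC(=O)c3cc4cccnc4n(-c4ccc(OC)cc4)c3=O)cc2)ccn1`, differs from compound 2 by methoxy in place of fluoro on an aromatic carbon. The measured step from compound 1 to compound 2 is the only one that touches this position, and it shows that fluoro in place of hydrogen there left the number essentially unchanged. For the measured compounds named here, nothing measured speaks directly to methoxy at that carbon, so the expectation rests on the small size of the one known step at that position and on the shared remainder of the two structures. Compound 3 is therefore expected to give 130 nM, with a range from 60 nM to 280 nM, which corresponds to an expected step of a 1.1-fold higher number from compound 2 to compound 3 (0.03 log units; within the scatter), one not clearly beyond the scatter in either direction.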

Compound 3, half-maximal inhibitory concentration: 1730 nM
Beside the measured number, compound 3's estimate is 13-fold (1.12 log units) below it; the measured number lies above the stated range.
By their numbers in this assay, from the lowest: compounds 1 and 2 (each within the scatter of the next); then compound 3.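

In this assay this aromatic carbon proves not to be indifferent to what it carries: methoxy in place of fluoro gives a 14-fold higher number from compound 2 to compound 3 (1.16 log units; beyond the scatter) and methoxy in place of hydrogen gives a 16-fold higher number from compound 1 to compound 3 (1.20 log units; beyond the scatter) with both steps large and beyond the scatter. Fluoro in place of hydrogen had given only a 1.1-fold higher number from compound 1 to compound 2 (0.04 log units; within the scatter) and so the tolerance seen there holds for those two groups and not for the position as a whole. Methoxy brings two heavy atoms and one hydrogen-bond acceptor to this carbon where fluoro brings one heavy atom and no acceptor, yet nothing given here says which of these differences, if either, lies behind the higher number.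

On these data alone, whether the oxygen or the added carbon matters more stays open: a hydroxyl, a methyl or an ethoxy group at this carbon would help to separate the two. Also open, as far as these compounds go, is whether a chlorine, an amine or a carboxylic acid here would read like compound 1 and compound 2 or like compound 3.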